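A few compounds are considered here, and "the series" means these few. Any claim that something is new, unique, unknown or untested is made for them only; others in the source may bear on it.

Measured in an ADME assay on the whole organism (Mus musculus, strain C57BL/6J) for pharmacokinetics, with a stated time of 24 h, at a dose of 2 mg/kg by the intravenous route; on this read-out higher numbers stand for fast clearance and lower numbers for slow clearance:
- compound 1 `CCCCOc1nc(OCC(C)(C)O)c(-c2ccc(S(C)(=O)=O)cc2)cc1CO`: 101 mL/min/kg
- compound 2 `CCCCOc1nc(OCC(C)(C)O)c(-c2ccc(S(C)(=O)=O)cc2)cc1C(C)(C)O`: 58.8 mL/min/kg

Among the compounds with values here, compound 1 gives 101 mL/min/kg, the only other number being that of compound 2 at 58.8 mL/min/kg, and the two lie within the scatter of each other. Compound 3 `CCCCOc1nc(-c2ccc(F)cc2)c(-c2ccc(S(C)(=O)=O)cc2)cc1CO` is the next to be read. It departs from compound 1 in one place: 4-fluorophenyl in place of 2-hydroxy-2-methylpropoxy on an aromatic carbon. It carries 4-fluorophenyl in place of 2-hydroxy-2-methylpropoxy, next to the ring nitrogen and para to a hydroxymethyl group.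

Within the data shown here, the one measured step, a 1.7-fold lower number from compound 1 to compound 2 (0.23 log units; within the scatter), swaps hydroxymethyl for 1-hydroxy-1-methylethyl and leaves 2-hydroxy-2-methylpropoxy untouched. Among the measured compounds shown here, it therefore bears only loosely on this change, and no measurement yet tests a replacement at the place that changes here. With so little to go on, no clear direction can be argued, and no shift beyond the scatter is expected. The expected step is a 1.4-fold lower number from compound 1 to compound 3 (0.16 log units; within the scatter), and this estimate is weakly held. For compound 3 the estimated clearance is 70 mL/min/kg, with an expected range of 30 mL/min/kg to 140 mL/min/kg.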

Compound 3, clearance: 32.2 mL/min/kg
Compound 3: middle estimate off by 2.2-fold (0.34 log units), on the high side, and the stated range covers the measured number.
By their numbers in this assay, from the lowest: compounds 3, 2 and 1 (each within the scatter of the next, the first and the last beyond it).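

Within the data shown here, at the position next to the ring nitrogen, this assay gives the first reading of a replacement: a 3.1-fold lower number from compound 1 to compound 3 (0.50 log units; beyond the scatter). Among these compounds, this shows that the number responds to the group at this position, with the butoxy and hydroxymethyl groups held constant, whereas the only earlier step, made at the hydroxymethyl group, stayed within the scatter. The change swaps a chain with 1 hydrogen-bond donor and 2 hydrogen-bond acceptors for a six-membered aromatic ring with 0 of each that also carries fluorine, so several features change together, and no supporting data link the step to any one of them.

From the compounds shown here alone, it remains open whether the step follows from the aromatic ring, the fluorine or the loss of the hydroxyl-bearing chain; plain phenyl, cyclohexyl and a simple ethoxy chain at this position would help to separate these. Also open, going by these compounds, is whether 1-hydroxy-1-methylethyl in place of hydroxymethyl would give a similar result when 4-fluorophenyl occupies this position.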